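Removing a Chloro Group from Compound 3

A few compounds are considered here, and "the series" means these few. Any claim that something is new, unique, unknown or untested is made for them only; others in the source may bear on it.

Measured compounds:
compound 1, `O=C(CSC(=S)N[C@H]1CCOC1=O)Nc1ccc(Cl)cc1`: > 128000 nM
compound 2, `O=C(CSC(=S)N[C@H]1CCOC1=O)Nc1ccc(Cl)cc1Cl`: > 128000 nM
compound 3, `O=C(CCl)Nc1ccc(C(=O)/C=C/c2ccc(Cl)cc2)cc1`: 8160 nM

Three compounds have been run in a functional assay on SMMC-7721 cells (Homo sapiens) for cytotoxicity, read by MTT assay, with a stated time of 72 h; a higher number here means a weaker inhibitor, a lower number a stronger inhibitor. Among the measured compounds shown here, compound 3 gives 8160 nM and is the only one with a real number. For compound 1 the result is a limit of the assay, > 128000 nM. For compound 2 the result is likewise a limit, > 128000 nM. The step from compound 2 to compound 1, a step that the two limits leave unreadable from compound 2 to compound 1, cannot be sized because of the limit of > 128000 nM in this assay, at which 2 of the 3 values shown sit. The difference between the core of compound 3 and the core of compound 2 is not broken down here.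

Compound 4, `O=C(CCl)Nc1ccc(C(=O)/C=C/c2ccccc2)cc1`, has not yet been measured. It differs from compound 3 by hydrogen in place of chloro on an aromatic carbon. The change from compound 2 to compound 1 is hydrogen in place of chloro on an aromatic carbon. The two are the same kind of change, but the surroundings differ: in compound 3 the place is para to a large group, whereas in compound 2 it is ortho to a large group and meta to a chloro group.

Since the earlier step is unreadable, the expectation for compound 4 rests only on the value of compound 3, 8160 nM, and on the small size of the change. Compound 4 is therefore expected to differ from compound 3 by about a 1.5-fold higher number from compound 3 to compound 4 (0.17 log units; within the scatter). The estimate for compound 4 in this assay is 12000 nM, expected to lie between 4000 nM and 40000 nM.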

Compound 4, half-maximal inhibitory concentration: 12600 nM
Compound 4: middle estimate off by 1.1-fold (0.02 log units), on the low side; the range from low to high includes it.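

In this assay, putting hydrogen in place of the chloro on an aromatic carbon, which turns 4-chlorophenyl into phenyl, gives a 1.5-fold higher number from compound 3 to compound 4 (0.19 log units; within the scatter); on the core of compound 3, then, the two groups cannot be told apart at this place. The same kind of change, from compound 2 to compound 1, cannot be read and so cannot be set beside this step, because both of those compounds sit at a limit of the assay rather than at a number: the limit of > 128000 nM in this assay, at which 2 of the 4 values shown sit. The series therefore offers a single readable case of the change, on one core, and it shows neither that the change carries over to the core of compound 2 nor that it fails to.

The compounds shown leave open what a methoxy group, a fluoro group or an amine would give in place of the hydrogen of compound 4, on that aromatic carbon para to a large group. They also leave open how the change would read on a second core where both partners give real numbers, so that two steps could be compared directly.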